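A Methyl Group Moved to a Different Ring

The source may report more compounds than this note shows. Statements on the series, on what has been measured and on what is new or still open speak of the compounds shown alone.

Compound 1 `COC(=O)[C@@]1(C)CCC=C2[C@@H]1CC[C@@H](C)[C@]2(C)Cc1c[nH]c2ccc(C(F)(F)F)cc12` and compound 2 `COC(=O)[C@@]1(C)CCC=C2[C@@H]1CC[C@@H](C)[C@]2(C)Cc1c(C)[nH]c2ccc(C(F)(F)F)cc12` share one core; compound 3 `COC(=O)[C@@]1(C)CC[C@@H]2C3=C1CC[C@@H](C)[C@]3(C)Cc1c2[nH]c2ccccc12` and compound 4 `COC(=O)[C@@]1(C)CC[C@@H]2C3=C1CC[C@@H](C)[C@]3(C)Cc1c2[nH]c2ccc(C)cc12` share another. How the two cores differ is not broken down here. In a functional assay on WiDr cells (Homo sapiens) for inhibition, read by sulforhodamine B assay, with a stated time of 48 h (on this read-out lower numbers stand for stronger inhibition of growth and higher numbers for weaker inhibition of growth), compound 1 gives 18000 nM, and compound 2 gives 21000 nM. The step between them, a 1.2-fold higher number from compound 1 to compound 2 (0.07 log units; within the scatter), comes from methyl in place of hydrogen on an aromatic carbon. Compound 3 stands apart: in this assay compound 3 gives 4000 nM, the lowest of the three numbers, with gaps to compound 1 and compound 2 that lie beyond the scatter.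

Compound 4 has not been measured. It differs from compound 3 by methyl in place of hydrogen on an aromatic carbon. Going by the values given here, this is the same kind of change as the one from compound 1 to compound 2, but not the same: there the methyl entered on a five-membered aromatic ring with 1 nitrogen, next to the ring nitrogen and next to the ring atom that bears a large group, whereas here it enters on a six-membered aromatic ring of carbon only, meta to a fused ring and para to a fused ring. Among the compounds with values here, the only measured example of adding a methyl, a 1.2-fold higher number from compound 1 to compound 2 (0.07 log units; within the scatter), stayed within the scatter. For compound 4 the expected step is a 1.1-fold lower number from compound 3 to compound 4 (0.06 log units; within the scatter), a small one, resting on the measured 1.2-fold higher number from compound 1 to compound 2 (0.07 log units; within the scatter) and widened in its uncertainty by the different place. Compound 4 is therefore expected to give about 3500 nM in this assay, within a range from 1500 nM to 9000 nM.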

Compound 4, concentration for 50% growth inhibition: 19000 nM
The estimate for compound 4 lay 5.4-fold (0.73 log units) below the measured number, and the stated range ends below it.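

In this assay, putting methyl in place of hydrogen on the six-membered aromatic ring of carbon only gives a 4.8-fold higher number from compound 3 to compound 4 (0.68 log units; beyond the scatter), so growth inhibition is weaker after the change. One kind of change, a single added methyl on an aromatic carbon, therefore does not keep its size from one core to the other in this series: the same change on two cores in this assay, a 1.2-fold higher number (0.07 log units; within the scatter) from compound 1 to compound 2 and a 4.8-fold higher number (0.68 log units; beyond the scatter) from compound 3 to compound 4, 4.1-fold (0.61 log units) apart, beyond the scatter of two such steps This does not show that the core alone sets the size of the step, since the two pairs also differ in which ring takes the methyl, and compound 1 and compound 2 carry a trifluoromethyl group that compound 3 and compound 4 lack.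

The compounds shown leave open whether the weaker inhibition belongs to methyl in particular or would follow other groups at this place on the six-membered ring, such as a fluorine atom, a methoxy group or a nitrile. They also leave open whether a methyl on the aromatic rings of other cores in this series would give a step nearer to the small one or the larger one, as two steps cannot settle a general rule.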